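Swapping the Aryl Group on the Urea-Type Nitrogen

The source may hold more compounds than are shown below. What is called first, only, known or untested is meant among the compounds shown, and "the series" means these compounds.

Compound 1, `Cn1ncnc1-c1cc(Oc2ccc(NC(=O)Nc3cccc(C(F)(F)F)c3)cc2F)ccn1`: in a functional assay on NCI-H460 cells (Homo sapiens) for antiproliferative activity, read by MTT assay, with a stated time of 72 h (on this read-out lower numbers stand for stronger inhibition and higher numbers for weaker inhibition), compound 1 gives 11600 nM
Compound 2, `CN(C)CCn1cnnc1-c1cc(Oc2ccc(NC(=O)Nc3cccc(C(F)(F)F)c3)cc2F)ccn1`: compound 2 gives 2150 nM
Compound 3, `CCN(CC)CCn1cnnc1-c1cc(Oc2ccc(NC(=O)Nc3cccc(C(F)(F)F)c3)cc2F)ccn1`: compound 3 gives 9870 nM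

Compound 3 gives the second highest of these three numbers. Its value lies within the scatter of that of compound 1, while compound 2 stands apart from it, as a 4.6-fold higher number from compound 2 to compound 3 (0.66 log units; beyond the scatter) shows. Compound 4, `CCN(CC)CCn1cnnc1-c1cc(Oc2ccc(NC(=O)Nc3ccc(Cl)cc3Cl)cc2F)ccn1`, keeps everything in compound 3 except one group: 2,4-dichlorophenyl in place of 3-(trifluoromethyl)phenyl on an amide-type nitrogen. Going by the values given here, none of the measured steps touches that part of the molecule. a 5.4-fold lower number from compound 1 to compound 2 (0.73 log units; beyond the scatter) and a 1.2-fold lower number from compound 1 to compound 3 (0.07 log units; within the scatter) change the group at the far end of the shared core, and a 4.6-fold higher number from compound 2 to compound 3 (0.66 log units; beyond the scatter) exchanges dimethylamino for diethylamino on a saturated chain carbon. No measured comparison therefore bears directly on the change from compound 3 to compound 4, and no step beyond the scatter is expected in this assay. The expected step is a 1.2-fold lower number from compound 3 to compound 4 (0.09 log units; within the scatter). Compound 4 is estimated to give about 8000 nM, within a wide range from 2500 nM to 25000 nM.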

Compound 4, half-maximal inhibitory concentration: 5380 nM
Compound 4: the middle estimate sits 1.5-fold (0.17 log units) above what was measured, within the range that was stated.
By their numbers in this assay, from the lowest: compound 2; then compounds 4, 3 and 1 (each within the scatter of the next, the first and the last beyond it).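

Going by these compounds alone, this is the first reading at the aryl group on the amide-type nitrogen, and in this assay the exchange of 3-(trifluoromethyl)phenyl for 2,4-dichlorophenyl gives a 1.8-fold lower number from compound 3 to compound 4 (0.26 log units; within the scatter), so compounds 3 and 4 cannot be told apart. At least in this diethylamino series, this position accepts a different substitution pattern, with chlorine in place of fluorine-bearing carbon, without a change that can be separated from assay noise, whereas the smaller exchange at the other end of the molecule, a 4.6-fold higher number from compound 2 to compound 3 (0.66 log units; beyond the scatter), does go beyond the scatter. Nothing available here explains either outcome.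

On these data alone, whether the same aryl exchange would behave alike on the dimethylamino side chain of compound 2 remains open. So does what an unsubstituted phenyl or a methoxyphenyl group would give on this nitrogen.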